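This account rests on a few compounds, and the source may have more. Where it says the series, first, only, none or still open, it means among the compounds named here.

Measured so far:
- Compound 1 `COC(=O)C1=CO[C@@H](O[C@@H]2O[C@H](COC(c3ccccc3)(c3ccccc3)c3ccccc3)[C@@H](OC(=O)O)[C@H](OC(C)=O)[C@H]2OC(C)=O)[C@@H]2[C@@H](C)[C@@H](OC(C)=O)C[C@H]12`: 0.82 ug/mL
- Compound 2 `COC(=O)C1=CO[C@@H](O[C@@H]2O[C@H](CO)[C@@H](OC(C)=O)[C@H](OC(C)=O)[C@H]2OC(C)=O)[C@@H]2[C@@H](C)[C@@H](OC(C)=O)C[C@H]12`: "not active" (no number reported)

In a functional assay on COLO 320 cells (Homo sapiens) for cytotoxicity, read by MTT assay, with a stated time of 4 h (a lower number here means a stronger inhibitor, a higher number a weaker inhibitor), compound 2 has no single number and is reported as "not active" (no number reported). The next structure is compound 3 `COC(=O)C1=CO[C@@H](O[C@@H]2O[C@H](COC(=O)c3cccc([N+](=O)[O-])c3)[C@@H](OC(C)=O)[C@H](OC(C)=O)[C@H]2OC(C)=O)[C@@H]2[C@@H](C)[C@@H](OC(C)=O)C[C@H]12`. The change is (3-nitrophenyl)carbonyl in place of hydrogen on an oxygen on a saturated carbon, with (3-nitrophenyl)carbonyl in place of hydrogen on an oxygen on a saturated carbon. A step towards a measurable but modest value in this assay is expected, though another result without a number remains quite possible. Compound 1 stands at 0.82 ug/mL. Compound 1 also carries aromatic rings absent from compound 2. For compound 3 the estimated value is 5 ug/mL, with an expected range from 1 ug/mL to 30 ug/mL.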

Compound 3, half-maximal inhibitory concentration: 0.44 ug/mL
Estimate against measurement, compound 3: 11-fold (1.06 log units) above; the measured number lies below the stated range.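

Compound 2 has no reported number, which leaves its change to compound 3 unreadable as a step of any size. The compounds shown leave open what lies behind the activity of compound 3, and no measurement given here bears on that.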